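The source may report more compounds than this note shows. Statements on the series, on what has been measured and on what is new or still open speak of the compounds shown alone.

Of the compounds shown here, three have been tested in a functional assay on HT-29 cells (Homo sapiens) for cytotoxicity, read by sulforhodamine B assay, with a stated time of 48 h, tested at 1 uM; a lower number here means a stronger effect, a higher number a weaker effect of the compound at the concentration tested. Compound 1 `COc1ccc(-c2cc(/C=C/C(=O)c3ccc(N)cc3)[nH]n2)cc1` gives 97%, compound 2 `COc1cc(-c2cc(/C=C/C(=O)c3ccc(N)cc3)[nH]n2)cc(OC)c1OC` gives 82%, and compound 3 `COc1cc(-c2cc(/C=C/C(=O)c3ccc(Cl)c(Cl)c3)[nH]n2)cc(OC)c1OC` gives 96%. Going by the values given here, on these numbers compound 2 stands lowest: compound 3 lies a number 14 percentage points higher from compound 2 to compound 3 (beyond the scatter), and compound 1 stands higher still than compound 2, also beyond the scatter, though no single-site step joins compound 1 and compound 2.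

Compound 4 `COc1ccc(-c2cc(/C=C/C(=O)c3ccc(N)cc3)[nH]n2)cc1OC` is not yet measured in this assay. It differs from compound 2 by hydrogen in place of methoxy on an aromatic carbon. Among the compounds with values here, the one measured step, from compound 2 to compound 3, alters the aryl ketone end and so says little about a methoxy on the other ring. Within the data shown here, the only guidance is that compound 1, which carries fewer methoxy groups on that same ring, sits above compound 2 by more than the scatter, with compound 4 falling between the two in structure. A modest rise is therefore expected, a number 8 percentage points higher from compound 2 to compound 4 (within the scatter), within the reach of the scatter at its low end. Compound 4 is estimated at 90%, with a range from 78% to 100%.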

Compound 4, a percentage reported as activity, at one concentration (the size of the read-out at that concentration, not a potency): 99%
For compound 4 the middle estimate is 9 percentage points below the measured one; the measured number falls inside the stated range.
By their numbers in this assay, from the lowest: compound 2; then compounds 3, 1 and 4 (each within the scatter of the next).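

In this assay, going by these compounds alone, the methoxy ortho to a methoxy group and meta to a large group proves to count on its own: hydrogen in its place gives a number 17 percentage points higher from compound 2 to compound 4 (beyond the scatter), the first single-site step on this ring. The other new step, methoxy in place of hydrogen on an aromatic carbon, gives a number 2 percentage points higher from compound 1 to compound 4 (within the scatter), so that single methoxy change leaves compound 1 and compound 4 inseparable, and on this ring only compound 2 stands apart from them. No measurement shown here accounts for this difference between the two methoxy steps.

The compounds shown leave open whether a hydroxy group or a fluorine atom at this position would keep the number as low as methoxy does. They also leave open whether hydrogen in place of this methoxy would give a similar step with the 3,4-dichlorophenyl group of compound 3 on the carbonyl carbon.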